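Isopropyl in place of 2-carboxyethyl: a solubility step unread

This account rests on a few compounds, and the source may have more. Where it says the series, first, only, none or still open, it means among the compounds named here.

Measured so far in a physicochemical assay for solubility, in phosphate buffer, at pH 7.4; a lower number here means a less soluble compound, a higher number a more soluble compound:
Compound 1 `O=C(O)CCCCCNC(=O)NC1CCCCC1`: > 500000 nM
Compound 2 `N=C(N)NCCC[C@H](NC(=O)CCCCCNC(=O)NC1CCCCC1)C(=O)O`: > 500000 nM
Compound 3 `O=C(O)CC[C@H](NC(=O)CCCCCNC(=O)NC1CCCCC1)C(=O)O`: > 500000 nM

Each of these three entries is a limit and not a number. Compound 3 stands at > 500000 nM, which is a limit. It has no place of its own in the series, for all three compounds sit at one mark: the limit of > 500000 nM in this assay, at which 3 of the 3 values shown sit.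

The next compound is compound 4 `CC(C)[C@H](NC(=O)CCCCCNC(=O)NC1CCCCC1)C(=O)O`, which has not yet been measured. It carries isopropyl in place of 2-carboxyethyl on a saturated chain carbon bound to an amide-type nitrogen and a carbonyl carbon.

For the measured compounds named here, the one measured step that bears on this change is a step that the two limits leave unreadable from compound 2 to compound 3. That step offers no size to carry over, so the expectation in this assay is for no step beyond the usual scatter, in either direction. A further limit, rather than a number, is the more likely report for compound 4. The expected step is a number no higher from compound 3 to compound 4 (the limit leaves the size open), and this is an estimate only. For compound 4 the estimated solubility is 500000 nM, with an expected range of 250000 nM to 1000000 nM.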

Compound 4, solubility: > 500000 nM
Compound 4 ended at the assay's limit (the forecaster's own chance of this, stated with the estimate: 80%); the middle value lies on the limit itself.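

In this assay compound 4 gives > 500000 nM, which is a limit and not a number. No step can be read between compound 4 and compound 1, compound 2 or compound 3, as all four sit at one mark: the limit of > 500000 nM in this assay, at which 4 of the 4 values shown sit.

The compounds shown leave open how the true solubility values of these four compounds compare with one another.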